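Moving One Fluorine Atom Within a Shared Core

The source may hold more compounds than are shown below. What is called first, only, known or untested is meant among the compounds shown, and "the series" means these compounds.

Compound 1 `Oc1ccccc1-c1cc(-c2ccc(F)cc2)cc(-c2ccccc2O)n1`: in a functional assay on HeLa cells (Homo sapiens) for inhibition (a lower number here means a stronger inhibitor, a higher number a weaker inhibitor), compound 1 reaches only the assay limit > 50000 nM.
Compound 2 `Oc1cccc(-c2cc(-c3ccc(F)cc3)cc(-c3ccccc3O)n2)c1`: in this assay compound 2 reaches only the assay limit > 50000 nM.
Compound 3 `Oc1ccc(-c2cc(-c3cccc(F)c3)cc(-c3ccccc3O)n2)cc1`: in this assay compound 3 reaches only the assay limit > 50000 nM.

Compound 3 therefore stands at a limit, not at a number, and every value shown sits there (the limit of > 50000 nM in this assay, at which 3 of the 3 values shown sit). Within the data shown here, the single readable step between measured compounds, a step that the two limits leave unreadable from compound 1 to compound 2, runs from one limit to another and has no size. Compound 4 `Oc1ccc(-c2cc(-c3ccc(F)cc3)cc(-c3ccccc3O)n2)cc1` arises from compound 3 by 4-fluorophenyl in place of 3-fluorophenyl on an aromatic carbon. Among the measured compounds shown here, no measured step bears on this change, and the values of compound 1 and compound 2 give nothing to compare. Compound 4 is expected to give a limit again in this assay. The step that the limit leaves unreadable from compound 3 to compound 4 is expected to be none beyond the scatter. The estimate for compound 4 is 70000 nM, within a range from 20000 nM to 250000 nM.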

Compound 4, half-maximal inhibitory concentration: > 50000 nM
Compound 4: only a limit was reported; the forecaster's own chance of this, stated with the estimate: 85%; the middle value is on the limit's open side.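

In this assay compound 4 gives only a limit, > 50000 nM, so the steps to it from compound 1, compound 2 and compound 3 cannot be read: the limit of > 50000 nM in this assay, at which 4 of the 4 values shown sit.

As far as these compounds go, whether moving the fluorine or the hydroxyl group changes inhibition at all remains open.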